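The source may hold more compounds than are shown below. What is called first, only, known or untested is meant among the compounds shown, and "the series" means these compounds.

Measured compounds:
- compound 1, `Oc1ccccc1/C=N/c1nnc(SCc2nnc(-c3ccccc3Cl)o2)s1`, 31800 nM
- compound 2, `Oc1ccccc1/C=N/c1nnc(SCc2nnc(-c3ccc(Cl)cc3)o2)s1`, 2840 nM

In a functional assay on SMMC-7721 cells (Homo sapiens) for inhibition, read by CCK-8 assay (a higher number here means a weaker inhibitor, a lower number a stronger inhibitor), compound 1 gives the highest of the two numbers; its nearest neighbour is compound 2, and the move there is an 11-fold lower number from compound 1 to compound 2 (1.05 log units; beyond the scatter), a change of 4-chlorophenyl in place of 2-chlorophenyl on an aromatic carbon. The compound still to be measured is compound 3, `Oc1ccccc1/C=N/c1nnc(SCc2nnc(-c3ccccc3Br)o2)s1`. It differs from compound 1 by bromo in place of chloro on an aromatic carbon; cut one bond further out, this reads 2-chlorophenyl to 2-bromophenyl, on an aromatic carbon of a six-membered aromatic ring of carbon only, ortho to a large group.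

For the measured compounds named here, no measured step exchanges one halogen for another at the same ring position. Going by the values given here, the only step known, from compound 1 to compound 2, moves the chlorine to a different position rather than replacing it, so it does not bear directly on the change to compound 3. With nothing in the data to point either way, compound 3 is expected to stay close to compound 1 in this assay, the estimated step being a 1.3-fold lower number from compound 1 to compound 3 (0.10 log units; within the scatter), not beyond the scatter. The estimate for compound 3 is 25000 nM, in the range 8000 nM to 80000 nM.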

Compound 3, half-maximal inhibitory concentration: 6780 nM
The estimate for compound 3 lay 3.7-fold (0.57 log units) above the measured number; the whole stated range lies above it.
By their numbers in this assay, from the lowest: compound 2; then compound 3; then compound 1.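

In this assay, the identity of the halogen at this ring position, ortho to a large group, proves to matter: bromo in place of chloro gives a 4.7-fold lower number from compound 1 to compound 3 (0.67 log units; beyond the scatter). For the compounds shown here, until now, the only change seen on this phenyl ring was a shift from the 2-chlorophenyl group to the 4-chlorophenyl group, so the series is now seen to respond to the halogen itself as well as to where it sits, although the 2-bromophenyl group still falls short of the 4-chlorophenyl group, with a 2.4-fold higher number from compound 2 to compound 3 (0.38 log units; beyond the scatter). No measurement available here bears on what lies behind these differences.

The compounds shown leave open whether the change from chloro to bromo would continue in the same direction with iodo, and how a methoxy group or an amine would behave in the same place. They also leave open whether a 4-bromophenyl group would go beyond the 4-chlorophenyl group, and whether the order of the three compounds would hold outside this assay.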